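A Dimethoxyphenyl Swap on an Acetyl Compound

A few compounds are considered here, and "the series" means these few. Any claim that something is new, unique, unknown or untested is made for them only; others in the source may bear on it.

In a functional assay on HL-60 cells (Homo sapiens) for cytotoxicity, read by MTT assay, with a stated time of 48 h (a lower number here means a stronger inhibitor, a higher number a weaker inhibitor), compound 3 `COc1cc(-n2c(-c3ccccc3)cn(C(C)=O)c2=O)cc(OC)c1OC` gives 5600 nM. This lies within the scatter of compound 1 `COc1cc(NC(=O)n2cc(-c3ccc(O)cc3)n(-c3cc(OC)c(OC)c(OC)c3)c2=O)cc(OC)c1OC` at 6300 nM and of compound 2 `COc1ccc(-c2cn(C(=O)Nc3cc(OC)c(OC)c(OC)c3)c(=O)n2-c2cc(OC)c(OC)c(OC)c2)cc1OC` at 6500 nM, so the three cannot be told apart. Compound 4 `COc1ccc(-c2cn(C(C)=O)c(=O)n2-c2cc(OC)c(OC)c(OC)c2)cc1OC` differs from compound 3 in one place, with 3,4-dimethoxyphenyl in place of phenyl on an aromatic carbon. Within the data shown here, only one measured step bears on this. Putting 3,4-dimethoxyphenyl in place of 4-hydroxyphenyl gave a 1.0-fold higher number from compound 1 to compound 2 (0.01 log units; within the scatter), which is within the scatter. That step began from a different group on a different compound, so it is indirect evidence. No change beyond the scatter is expected, and the estimated step is a 1.0-fold higher number from compound 3 to compound 4 (0.02 log units; within the scatter). Compound 4 is expected at about 5800 nM, with an estimated range of 2800 nM to 12000 nM.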

Compound 4, half-maximal inhibitory concentration: 12200 nM
For compound 4 the middle estimate is 2.1-fold (0.32 log units) below the measured one; the measured number lies above the stated range.
By their numbers in this assay, from the lowest: compounds 3, 1, 2 and 4 (each within the scatter of the next, the first and the last beyond it).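

On the acetyl compounds this position does respond: 3,4-dimethoxyphenyl in place of phenyl gives a 2.2-fold higher number from compound 3 to compound 4 (0.34 log units; beyond the scatter) in this assay, a modest loss of strength. The same group entering in place of 4-hydroxyphenyl gave only a 1.0-fold higher number from compound 1 to compound 2 (0.01 log units; within the scatter), so the two swaps do not read alike, though they start from different groups on different compounds.

On these data alone, how a 4-aminophenyl group or a carboxylic acid on that phenyl ring would fare at this position remains open. Nothing shown here explains the step.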